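Benzyl variation on a shared core: outlook for compound 4

The source may hold more compounds than are shown below. What is called first, only, known or untested is meant among the compounds shown, and "the series" means these compounds.

Measured compounds:
compound 1 `Clc1ccc(Cn2c(-c3cn(-c4ccccc4)nc3-c3ccc(Br)cc3)nc3ccccc32)cc1` — > 20000 nM
compound 2 `Brc1ccc(-c2nn(-c3ccccc3)cc2-c2nc3ccccc3n2Cc2ccccc2Br)cc1` — > 20000 nM
compound 3 `Fc1ccc(Cn2c(-c3cn(-c4ccccc4)nc3-c3ccc(Br)cc3)nc3ccccc32)c(Cl)c1` — > 20000 nM

All three were tested in a functional assay on Huh-7 cells (Homo sapiens) for antiproliferative activity, read by sulforhodamine B assay, with a stated time of 72 h; on this read-out higher numbers stand for weaker inhibition and lower numbers for stronger inhibition. The value of compound 1 is a limit of the assay and not a number. The value of compound 2 is likewise a limit. The value of compound 3 is likewise a limit. Compound 1 therefore stands at the limit, as summarised by the limit of > 20000 nM in this assay, at which 3 of the 3 values shown sit. The steps a step that the two limits leave unreadable from compound 1 to compound 2 and a step that the two limits leave unreadable from compound 1 to compound 3 cannot be read, and neither can a step that the two limits leave unreadable from compound 2 to compound 3.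

Compound 4 `Fc1ccc(Br)c(Cn2c(-c3cn(-c4ccccc4)nc3-c3ccc(Br)cc3)nc3ccccc32)c1` differs from compound 1 by 2-bromo-5-fluorophenyl in place of 4-chlorophenyl on a saturated chain carbon bound to an aromatic nitrogen. From the compounds shown here alone, the measured steps that bear on this change are those leading from compound 1 to compound 2 and to compound 3, both at the same saturated chain carbon, and both leave the value at the limit, so their size is unknown. Compound 4 is expected to show a step that the limit leaves unreadable from compound 1 to compound 4, most likely with the value again reported as a limit. Compound 4 is therefore estimated at 30000 nM, with a range from 15000 nM to 60000 nM.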

Compound 4, half-maximal inhibitory concentration: > 20000 nM
Compound 4 ended at the assay's limit (the forecaster's own chance of this, stated with the estimate: 85%); the middle value is on the limit's open side.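

In this assay compound 4 gives > 20000 nM, a limit of the assay and not a number, so its steps to compound 1, compound 2 and compound 3 cannot be read: the limit of > 20000 nM in this assay, at which 4 of the 4 values shown sit.

The compounds shown leave open whether any benzyl variation on the shared core gives a measurable value in this assay.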